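A Naphthalen-1-yl Replacement and Its Expected Solubility

The source may report more compounds than this note shows. Statements on the series, on what has been measured and on what is new or still open speak of the compounds shown alone.

Of the compounds shown here, three built on one shared core have been measured in a physicochemical assay for solubility, with a stated time of 18 h, at pH 7.4; on this read-out lower numbers stand for lower solubility and higher numbers for higher solubility. Compound 1 `c1ccc(CCc2ccc3c(NCCCNCc4ccco4)ccnc3c2)cc1` gives 4200 nM. Compound 2 `COc1ccc(F)cc1CNCCCNc1ccnc2cc(CCc3ccccc3)ccc12` gives 4200 nM, and compound 3 `COc1cccc(CNCCCNc2ccnc3cc(CCc4ccccc4)ccc23)c1O` gives 4200 nM. Compound 1 stands level with both of them: the step of no change at the digits printed from compound 1 to compound 2 (within the scatter), the step of no change at the digits printed from compound 1 to compound 3 (within the scatter) and the step of no change at the digits printed from compound 2 to compound 3 (within the scatter) all lie within the scatter, so swapping the group on the saturated chain carbon bound to an amine nitrogen was accompanied by no change in solubility.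

Compound 4 `c1coc(CNCCCNc2ccnc3cc(-c4cccc5ccccc45)ccc23)c1` has not yet been measured. It differs from compound 1 in a single place: naphthalen-1-yl in place of phenethyl on an aromatic carbon. Among the compounds with values here, none of the measured steps touches this position; each of them alters only the group on the saturated chain carbon bound to an amine nitrogen. Within the data shown here, the record thus holds no step that bears directly on the change from compound 1 to compound 4, and the level values of compounds 1, 2 and 3 show only that this series sits near one solubility. Compound 4 is nonetheless expected to fall somewhat lower, a step of a 1.7-fold lower number from compound 1 to compound 4 (0.23 log units; within the scatter) in this assay. Compound 4 is estimated at 2500 nM, within a range of 800 nM to 8000 nM.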

Compound 4, solubility: 32000 nM
Beside the measured number, compound 4's estimate is 13-fold (1.11 log units) below it, and the stated range ends below it.
By their numbers in this assay, from the lowest: compounds 1, 2 and 3 (each within the scatter of the next); then compound 4.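

In this assay, the aromatic carbon of the shared core proves to be a place where a single change registers: naphthalen-1-yl in place of phenethyl gives a 7.6-fold higher number from compound 1 to compound 4 (0.88 log units; beyond the scatter). Within the data shown here, the earlier steps altered only the group on the saturated chain carbon bound to an amine nitrogen and all stayed within the scatter, so they could not show that this series responds to any change; this is the first step beyond the scatter, and it runs towards a higher number. The entering group has 10 heavy atoms against 8 for the leaving one, and neither has hydrogen-bond donors or acceptors, but nothing available accounts for the rise.

A single step cannot separate the presence of the fused naphthalen-1-yl from the loss of phenethyl, and a phenyl, benzyl or naphthalen-2-yl group on this aromatic carbon would bear on that question. As far as these compounds go, it also remains open whether the rise would hold with the 5-fluoro-2-methoxyphenyl or 2-hydroxy-3-methoxyphenyl groups of compound 2 and compound 3 in place of furan-2-yl.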